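This account rests on a few compounds, and the source may have more. Where it says the series, first, only, none or still open, it means among the compounds named here.

In a functional assay on BXPC-3 cells (Homo sapiens) for antiproliferative activity, read by MTT assay, with a stated time of 24 h (a lower number here means a stronger inhibitor, a higher number a weaker inhibitor), compound 1 (`CCn1c(C(=O)N[C@@H](C)C(=O)OC)ccc1C(CC)(CC)c1ccc(OCS(=O)(=O)c2ccccc2)c(C)c1`) gives 17900 nM. Compound 2 (`CCn1c(C(=O)N[C@H](C)C(=O)OC)ccc1C(CC)(CC)c1ccc(OCS(=O)(=O)c2ccccc2)c(C)c1`) gives > 50000 nM, which is a limit. As far as these compounds go, compound 3 (`CCn1c(C(=O)NCCC(=O)OC)ccc1C(CC)(CC)c1ccc(OCS(=O)(=O)c2ccccc2)c(C)c1`) gives > 50000 nM, also a limit, so its true standing stays open.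

Compound 4 (`CCn1c(C(=O)N[C@H](C)CO)ccc1C(CC)(CC)c1ccc(OCS(=O)(=O)c2ccccc2)c(C)c1`) carries 1-(hydroxymethyl)ethyl in place of 2-(methoxycarbonyl)ethyl on an amide-type nitrogen.

The readable steps at this nitrogen are an at least 2.7-fold higher number from compound 1 to compound 2 (0.44 log units; beyond the scatter) and an at least 2.7-fold higher number from compound 1 to compound 3 (0.44 log units; beyond the scatter), while a step that the two limits leave unreadable from compound 2 to compound 3. Neither readable step involves the entering group. Only compound 1 gives a number, and compound 3 remains a limit, so no large gain is expected.

The expected change is small: an at least 1.2-fold lower number from compound 3 to compound 4 (0.09 log units; that floor lies within the scatter). For compound 4 the estimated value is 40000 nM, with an expected range of 15000 nM to 80000 nM.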

Compound 4, half-maximal inhibitory concentration: 10000 nM
For compound 4 the middle estimate is 4.0-fold (0.60 log units) above the measured one; measured number outside the range, below it.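

With 1-(hydroxymethyl)ethyl on the amide-type nitrogen, a methoxycarbonyl group is not needed for a measurable number in this assay: the steps read an at least 5.0-fold lower number from compound 3 to compound 4 (0.69 log units; beyond the scatter) and an at least 5.0-fold lower number from compound 2 to compound 4 (0.69 log units; beyond the scatter). The values of compound 2 and compound 3 are limits of the assay, so neither step has a fixed size. For the compounds shown here, the one full comparison reads a 1.8-fold lower number from compound 1 to compound 4 (0.25 log units; within the scatter), which leaves hydroxymethyl and methoxycarbonyl level in the 1-substituted ethyl group. As far as these compounds go, how a carboxylic acid or a longer hydroxyalkyl chain on this nitrogen would stand remains open, as does the opposite configuration of the 1-(hydroxymethyl)ethyl group.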